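Sugar stereocentre change in an alkynyl nucleoside series

The source may report more compounds than this note shows. Statements on the series, on what has been measured and on what is new or still open speak of the compounds shown alone.

Measured so far:
compound 1 `CCCCC#Cc1cc2cn([C@@H]3O[C@H](CO)[C@@H](O)[C@@H]3O)c(=O)nc2o1` — > 144000 nM
compound 2 `CCCCCCCCC#Cc1cc2cn([C@@H]3O[C@H](CO)[C@@H](O)[C@H]3O)c(=O)nc2o1` — 49000 nM

Both compounds were tested in a functional assay on HEL cells (Homo sapiens) for cytotoxicity; on this read-out lower numbers stand for higher toxicity in this test and higher numbers for lower toxicity in this test. Compound 1 gives > 144000 nM, which is a limit of the assay and not a number; this is the limit of > 144000 nM in this assay, at which 1 of the 2 values shown sits. For the measured compounds named here, compound 2 gives 49000 nM, the only number recorded in this assay so far. Going by the values given here, no step between measured compounds that differ in one place is available, so the series carries no measured step yet.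

Compound 3 `CCCCCCCCC#Cc1cc2cn([C@@H]3O[C@H](CO)[C@@H](O)[C@@H]3O)c(=O)nc2o1` is still to be measured in this assay. (the two compounds have the same atoms and bonds and differ only in configuration as drawn: 1 of 4 stereo elements differ; a stereocentre at a saturated ring carbon is drawn R in compound 2 and S in compound 3). Among the compounds with values here, with no measured step on such a stereocentre, the direction of the change is open. A step from compound 2 to compound 3 of a 1.8-fold higher number from compound 2 to compound 3 (0.26 log units; within the scatter) toward lower toxicity is expected, with a step within the scatter also possible. Compound 3 is estimated at 90000 nM, with a range from 35000 nM to 230000 nM. A result reported only as a limit for compound 3 would not be surprising.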

Compound 3, minimum cytotoxic concentration: 49000 nM
Estimate against measurement, compound 3: 1.8-fold (0.26 log units) above, and the stated range covers the measured number.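

In this assay, for the compounds shown here, the change of a stereocentre at a saturated ring carbon from R to S gives no change at the digits printed from compound 2 to compound 3 (within the scatter), the first measured step on this centre, so on this chain the configuration at this position does not separate the two compounds: the fact that compounds 2 and 3 differ only in the configuration as drawn. With this sugar configuration held, butyl in place of hydrogen on a saturated chain carbon, four bonds along the chain from a triple-bonded carbon, gives an at least 2.9-fold lower number from compound 1 to compound 3 (0.46 log units; beyond the scatter), so of the two changes now measured, only the chain change gives a step beyond the scatter. For compound 1, > 144000 nM is a limit of the assay and not a number, so the full size of that step cannot be read: the limit of > 144000 nM in this assay, at which 1 of the 3 values shown sits.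

The compounds shown leave open whether the same stereocentre change would also give no step on the shorter chain of compound 1. They also leave open how this assay would respond to a longer chain, or to a chain carrying an amine or a carboxylic acid, and whether the absence of a stereocentre step would hold on such chains.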